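Methylsulfonyl in place of trifluoromethyl: working notes

This account rests on a few compounds, and the source may have more. Where it says the series, first, only, none or still open, it means among the compounds named here.

Half-life values in an ADME assay on microsomes from liver (Rattus norvegicus) for metabolic stability (a higher number here means that the compound lasts longer, a lower number that the compound disappears faster), follow
- compound 1 `COc1cc(OCc2csc(-c3ccc(C(F)(F)F)cc3)n2)c2cc(-c3cn4nc(OC)sc4n3)oc2c1` gives 1.42 h
- compound 2 `COc1cc(OCc2cccc(-c3ccc(C(F)(F)F)cn3)c2)c2cc(-c3cn4nc(OC)sc4n3)oc2c1` gives > 2 h (a limit of the assay, not a number)
- compound 3 `COc1cc(OCc2cccc(-c3cnc(OC)nc3)c2)c2cc(-c3cn4nc(OC)sc4n3)oc2c1` gives 1.03 h

Of the two actual numbers in this assay (the other entry being a limit), compound 1 and compound 3 lie within the scatter of each other.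

Compound 4 `COc1cc(OCc2csc(-c3ccc(S(C)(=O)=O)cc3)n2)c2cc(-c3cn4nc(OC)sc4n3)oc2c1` has not yet been measured. Its difference from compound 1 is methylsulfonyl in place of trifluoromethyl on an aromatic carbon. Within the data shown here, no measured pair makes this exact exchange.

Among the measured compounds shown here, the only measured step is an at least 1.9-fold lower number from compound 2 to compound 3 (0.28 log units; that floor lies within the scatter) (the one guide available). Only a floor is known for its size because of the limit of > 2 h in this assay, at which 1 of the 3 values shown sits, and that floor gives no firm size. That step also takes out a group carrying trifluoromethyl, but what enters there is not methylsulfonyl, so it bears on the present change only loosely.

No step beyond the scatter is therefore expected, with at most a slight drift to a lower number. The expected step, an estimate, is a 1.1-fold lower number from compound 1 to compound 4 (0.04 log units; within the scatter) (direction tentative). For compound 4 the expected half-life is 1.3 h (estimated range 0.65 h to 2.4 h).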

Compound 4, half-life: 1.12 h
The estimate for compound 4 lay 1.2-fold (0.06 log units) above the measured number; the range from low to high includes it.
By their numbers in this assay, from the lowest: compounds 3, 4 and 1 (each within the scatter of the next). At a limit, above all of these: compound 2.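

In this assay methylsulfonyl in place of trifluoromethyl now has a direct reading, with a 1.3-fold lower number from compound 1 to compound 4 (0.10 log units; within the scatter) on the shared core. At this place, on an aromatic carbon of a six-membered aromatic ring of carbon only and para to a large group, the half-life does not separate the two groups, even though the entering group counts 2 hydrogen-bond acceptors and the leaving group 0. Among these compounds, this step has a number at both ends, which the only earlier step, an at least 1.9-fold lower number from compound 2 to compound 3 (0.28 log units; that floor lies within the scatter), did not offer, and it is the first to concern this exact exchange.

The compounds shown leave open how a carboxylic acid, an amine or a longer chain at this same place would read in this assay, since only two groups have been compared there. Also open, going by these compounds, is how methylsulfonyl would read in the setting of compound 2, where the upper end of the read-out offers no number to compare against: the limit of > 2 h in this assay, at which 1 of the 4 values shown sits.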